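A chloro group added to compound 3

The source may hold more compounds than are shown below. What is called first, only, known or untested is meant among the compounds shown, and "the series" means these compounds.

Compound 1 `O=C(CN1CCN(c2nnc(Cc3ccccc3)c3ccccc23)CC1)Nc1c(F)cccc1F`: 84500 nM
Compound 2 `Cc1ccc(F)cc1NC(=O)CN1CCN(c2nnc(Cc3ccccc3)c3ccccc23)CC1`: "not active" (no number reported)
Compound 3 `Cc1ccccc1NC(=O)CN1CCN(c2nnc(Cc3ccccc3)c3ccccc23)CC1`: "not active" (no number reported)

In a functional assay on A549 cells (Homo sapiens) for cytotoxicity, read by MTT assay, with a stated time of 72 h (a higher number here means a weaker inhibitor, a lower number a stronger inhibitor), these three compounds share one core and differ in the substituted phenyl group of the amide. Only compound 1 gives a number. Compound 3 has no single value, and it is recorded as "not active" (no number reported). Compound 2 is the one other entry without a number, recorded as "not active" (no number reported).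

Compound 4 `Cc1cccc(Cl)c1NC(=O)CN1CCN(c2nnc(Cc3ccccc3)c3ccccc23)CC1` differs from compound 3 by one change, chloro in place of hydrogen on an aromatic carbon, turning 2-methylphenyl into 2-chloro-6-methylphenyl. Among the compounds with values here, no measured step shows what such a change does, so its size cannot be read from the data. Within the data shown here, at most a small step toward stronger inhibition in this assay is expected, and the only numerical guide is compound 1 at 84500 nM. Compound 4 may well also be reported without a number. If a number is reported, compound 4 is estimated at 80000 nM, with an expected range of 30000 nM to 200000 nM.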

Compound 4, half-maximal inhibitory concentration: 7420 nM
Compound 4: middle estimate off by 11-fold (1.03 log units), on the high side, outside the stated range (below it).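

In this assay compound 4 gives 7420 nM, whereas compound 3 is recorded as not active, so chloro in place of hydrogen, ortho to a large group and meta to the methyl group, turns an entry without a number into a measurable one, though the size of that change cannot be read without a value for compound 3. Within the data shown here, the one step that can be read, an 11-fold lower number from compound 1 to compound 4 (1.06 log units; beyond the scatter), puts 2-chloro-6-methylphenyl well ahead of 2,6-difluorophenyl on the amide nitrogen, showing that the choice of groups on this ring can move the value well beyond the scatter. The data at hand offer no evidence on why this happens.

The compounds shown leave open whether bromo, methoxy or an amine at this place would give a similar value. They also leave open how a 2-chlorophenyl amide, with no methyl group, would compare.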